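The source may report more compounds than this note shows. Statements on the series, on what has been measured and on what is new or still open speak of the compounds shown alone.

Compound 1 `CC(C)N(C(=O)C1CCCCCC1)c1cc(C#CC(C)(C)C)sc1C(=O)O` was examined in an ADME assay for protein binding, using equilibrium dialysis, at pH 7.4, tested at 2 uM (on this read-out lower numbers stand for a smaller free fraction and higher numbers for a larger free fraction), where compound 1 gives 0.11. For the measured compounds named here, the only other measured compound, compound 2 `CC(C)(C)C#Cc1cc(N(C(=O)[C@H]2CC[C@H](C)CC2)[C@H]2CC[C@H](O)CC2)c(C(=O)O)s1`, gives 0.19 in this assay. Of the two numbers, compound 1 is the smaller, but the gap to compound 2 falls within the usual scatter of repeated measurements, so the two cannot be told apart on this evidence.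

Compound 3 `CC(C)N(C(=O)C1CCCCC1)c1cc(C#CC(C)(C)C)sc1C(=O)O` has not yet been measured in this assay. It differs from compound 1 in a single place: cyclohexyl in place of cycloheptyl on a carbonyl carbon. The rest of the shared core is untouched. Going by the values given here, no pair of measured compounds shows this same change, so there is no precedent to draw on, and the expectation rests on compound 1's value 0.11 alone. The step of a 1.3-fold higher number from compound 1 to compound 3 (0.10 log units; within the scatter) is expected to be small, leaning toward a slightly larger free fraction, but not beyond the scatter. Compound 3 is accordingly estimated at 0.14, with a likely range from 0.09 to 0.22.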

Compound 3, unbound fraction: 0.18
For compound 3 the middle estimate is 1.3-fold (0.11 log units) below the measured one, within the range that was stated.
By their numbers in this assay, from the lowest: compounds 1, 3 and 2 (each within the scatter of the next).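

For the compounds shown here, compound 3 gives the first reading of a single change at this position, since compound 2 differs from compound 1 in more than one place. In this assay, cyclohexyl in place of cycloheptyl on a carbonyl carbon gives a step (a 1.6-fold higher number from compound 1 to compound 3 (0.21 log units; within the scatter)), so this pair cannot be told apart and the change of ring size, with the rest of the shared core untouched, has no effect that can be distinguished from repeat scatter. Nothing on hand speaks to what lies behind this small step, and with one pair it stands as a single observation, not a trend across ring sizes.

The two saturated carbon rings shown leave open whether a smaller ring such as cyclopentyl, an open chain such as n-hexyl, or a ring carrying a heteroatom, such as tetrahydropyranyl or piperidinyl, on the same carbonyl carbon would give a step beyond the scatter in this assay. Going by these compounds, it also remains open whether the same exchange of cycloheptyl for cyclohexyl would read alike on a core carrying a different group on the amide-type nitrogen, such as the hydroxycyclohexyl of compound 2.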